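Two Inactive Analogs and a Dimethoxyphenyl Exchange

The source may hold more compounds than are shown below. What is called first, only, known or untested is meant among the compounds shown, and "the series" means these compounds.

Compound 1 `Cc1cc(Cc2cccc(F)c2)c(=O)n(CC(=O)Nc2ccc(Br)cc2)n1` and compound 2 `Cc1cc(Cc2cccc(Cl)c2)c(=O)n(CC(=O)Nc2ccc(Br)cc2)n1` share one core and differ at a single aromatic carbon. In an assay on HL-60 cells for agonist activity at N-formyl peptide receptor 3 (Homo sapiens), read by calcium flux (a lower number here means that less compound is needed, a higher number that more compound is needed for the effect), compound 1 reaches only the limit of the measurement, > 50000 nM. In this assay compound 2 likewise reaches only the limit, > 50000 nM. The step that the two limits leave unreadable from compound 1 to compound 2 cannot be read because the limit of > 50000 nM in this assay, at which 2 of the 2 values shown sit, holds both values. Compound 2 therefore stands at the limit, with no measurable number to set it against.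

Compound 3 `COc1cc(Cc2cc(C)nn(CC(=O)Nc3ccc(Br)cc3)c2=O)cc(OC)c1` carries 3,5-dimethoxyphenyl in place of 3-chlorophenyl on a saturated chain carbon bound to an aromatic carbon. Within the data shown here, no measured step bears on this exchange, and the one step recorded is itself unreadable, so it lends no size to carry over. The author expects compound 3 most likely to remain at the limit again, with a modest chance of a readable value, estimating 40000 nM within 5000 nM to 100000 nM. The step of an at least 1.2-fold lower number from compound 2 to compound 3 (0.09 log units; that floor lies within the scatter) is thus expected to be small, if it appears at all.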

Compound 3, half-maximal effective concentration: > 50000 nM
Compound 3 ended at the assay's limit (the forecaster's own chance of this, stated with the estimate: 70%); at least 1.2-fold (0.09 log units) between middle value and limit.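

In this assay compound 3 gives only a limit, > 50000 nM. No step among compound 1, compound 2 and compound 3 can be read: the limit of > 50000 nM in this assay, at which 3 of the 3 values shown sit.

From the compounds shown here alone, whether any of these three compounds has a measurable value in this assay, and how the groups exchanged on the shared core would rank, remains open.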